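A few compounds are considered here, and "the series" means these few. Any claim that something is new, unique, unknown or untested is made for them only; others in the source may bear on it.

The measured compounds and their values:

compound 1, `CCCCCCOc1ccc(C(=O)/C=C/c2c(/C=C/c3ccc(OC)cc3)cc(OC)cc2OC)cc1`, in a functional assay on HepG2 cells (Homo sapiens) for antiproliferative activity, read by MTT assay, with a stated time of 48 h; on this read-out higher numbers stand for weaker inhibition and lower numbers for stronger inhibition: 16.2 ug/mL
compound 2, `COc1ccc(/C=C/c2cc(OC)cc(OC)c2/C=C/C(=O)c2cccc(Br)c2)cc1`, in this assay: 13 ug/mL
compound 3, `COc1ccc(/C=C/c2cc(OC)cc(OC)c2/C=C/C(=O)c2ccc(N)cc2)cc1`, in this assay: 7.5 ug/mL

Compound 3 carries the lowest of the three numbers in this assay. Compound 2 stands within the scatter of it, so the two cannot be told apart, while compound 1 lies beyond the scatter, as a 2.2-fold lower number from compound 1 to compound 3 (0.33 log units; beyond the scatter) shows; the change there was amino in place of hexyloxy on an aromatic carbon. The step of a 1.7-fold lower number from compound 2 to compound 3 (0.24 log units; within the scatter) is within the scatter and concerns a different part of the molecule.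

Compound 4, `CCCC(C)Oc1ccc(C(=O)/C=C/c2c(/C=C/c3ccc(OC)cc3)cc(OC)cc2OC)cc1`, differs from compound 3 in one place: 1-methylbutoxy in place of amino on an aromatic carbon. Among the compounds with values here, this runs the step from compound 1 to compound 3 backwards, an alkoxy chain again in place of the amino group, so a modest rise in the number of this assay is expected, in the direction of compound 1, although the chain here is shorter and branched and no measured pair tests that. Compound 4 is therefore expected to give 14 ug/mL in this assay, between 7 ug/mL and 28 ug/mL, a step of a 1.9-fold higher number from compound 3 to compound 4 (0.27 log units; within the scatter).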

Compound 4, half-maximal inhibitory concentration: 11.1 ug/mL
Beside the measured number, compound 4's estimate is 1.3-fold (0.10 log units) above it; the measured number falls inside the stated range.
By their numbers in this assay, from the lowest: compounds 3, 4, 2 and 1 (each within the scatter of the next, the first and the last beyond it).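

In this assay the step of a 1.5-fold higher number from compound 3 to compound 4 (0.17 log units; within the scatter) stays within the scatter, so on this aromatic carbon, para to a large group, 1-methylbutoxy cannot be told apart from amino, although hexyloxy can. The step of a 1.5-fold lower number from compound 1 to compound 4 (0.16 log units; within the scatter) is also within the scatter, so the two chains on this oxygen cannot be told apart, and the step of a 1.2-fold lower number from compound 2 to compound 4 (0.07 log units; within the scatter) likewise leaves no readable difference between 4-(1-methylbutoxy)phenyl and 3-bromophenyl on the carbonyl carbon. Within the data shown here, the only step beyond the scatter at this position therefore remains the one between amino and hexyloxy, and no supporting data bear on this result.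

From the compounds shown here alone, it remains open whether a straight butoxy chain would read differently from the branched 1-methylbutoxy chain. Going by these compounds, it is also open whether a hydroxy group or a carboxylic acid at this position would move the number beyond the scatter.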